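This account rests on a few compounds, and the source may have more. Where it says the series, first, only, none or still open, it means among the compounds named here.

Measured so far in a functional assay on SK-MEL-28 cells (Homo sapiens) for inhibition, read by sulforhodamine B assay, with a stated time of 48 h; on this read-out higher numbers stand for weaker inhibition of growth and lower numbers for stronger inhibition of growth:
compound 1 `Nc1cc(N)c2nc(-c3ccccc3)c(Oc3ccc(Cl)c(Cl)c3)nc2c1`: 21400 nM
compound 2 `CCOC(=O)[C@H](CCC(=O)O)NC(=O)c1ccc(Sc2nc3cc(N)cc(N)c3nc2-c2ccccc2)cc1`: 6760 nM
compound 3 `Nc1cc(N)c2nc(-c3ccccc3)c(Sc3ccc(F)cc3)nc2c1`: 23400 nM

Compound 3 carries the highest number of the three; its value and that of compound 1 sit within the scatter of each other, while compound 2 gives a distinctly lower number. Compound 4 `Nc1cc(N)c2nc(-c3ccccc3)c(Oc3ccc(F)cc3)nc2c1` is not yet measured. It differs from compound 3 by 4-fluorophenoxy in place of (4-fluorophenyl)sulfanyl on an aromatic carbon. Among the measured compounds shown here, the only measured step touching this part of the core is a 1.1-fold higher number from compound 1 to compound 3 (0.04 log units; within the scatter), which exchanged the linking atom together with the halogens at once; no step isolates the sulfur-for-oxygen exchange alone. With that combined step flat, no shift beyond the scatter is expected for compound 4, and a 1.1-fold lower number from compound 3 to compound 4 (0.03 log units; within the scatter) is the estimated step. Compound 4 is estimated at 22000 nM, range 9000 nM to 55000 nM.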

Compound 4, concentration for 50% growth inhibition: 19500 nM
Estimate against measurement, compound 4: 1.1-fold (0.05 log units) above; measured number inside the range.
By their numbers in this assay, from the lowest: compound 2; then compounds 4, 1 and 3 (each within the scatter of the next).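

In this assay, the step of a 1.2-fold lower number from compound 3 to compound 4 (0.08 log units; within the scatter) changes only the linking atom, sulfur to oxygen, with the 4-fluorophenyl group kept. The step of a 1.1-fold lower number from compound 1 to compound 4 (0.04 log units; within the scatter) changes only the halogens on the phenoxy ring, so each part of the earlier combined exchange now reads separately, and neither moves the number beyond the scatter. No data are at hand that explain these flat steps.

Still open, going by these compounds, is whether an amine or a longer alkyl chain on this carbon would shift the number. Also open, on these data alone, is whether the carboxylic acid side chain of compound 2 is what sets its value apart.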